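From compound 2 to its nitro analogue

This account rests on a few compounds, and the source may have more. Where it says the series, first, only, none or still open, it means among the compounds named here.

Measured compounds:
- Compound 1 `Cc1ccc(/N=N/c2ccc(NCCCN(C)C)cc2)cc1` gives 50000 nM
- Compound 2 `CN(C)CCCNc1ccc(/N=N/c2ccccc2)cc1` gives 30000 nM
- Compound 3 `Clc1ccc(/N=N/N2CCCC2)cc1` gives > 100000 nM (a limit)

These values come from an ADME assay on Vero cells (Chlorocebus sabaeus) for cytotoxicity, read by crystal violet staining; a lower number here means that less compound is tolerated, a higher number that more compound is tolerated. For compound 3 the value is a limit and not a number. Among the compounds with values here, compound 2 sits at 30000 nM, and the only measured step reaching it is a 1.7-fold lower number from compound 1 to compound 2 (0.22 log units; within the scatter), which puts hydrogen in place of methyl on an aromatic carbon. Compound 2 therefore cannot be told apart from compound 1 in this assay.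

Compound 4 `CN(C)CCCNc1ccc(/N=N/c2ccc([N+](=O)[O-])cc2)cc1` changes compound 2 in one place, (nitro in place of hydrogen on an aromatic carbon), with nitro in place of hydrogen on an aromatic carbon. Within the data shown here, none of the measured compounds carries nitro, so the step of a 1.7-fold lower number from compound 1 to compound 2 (0.22 log units; within the scatter) is only a weak guide. It still gives no reason to expect a move beyond the scatter, in either direction. The expected step is a 1.2-fold lower number from compound 2 to compound 4 (0.08 log units; within the scatter). Compound 4 is estimated at 25000 nM. The expected range for compound 4 runs from 8000 nM to 70000 nM.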

Compound 4, half-maximal cytotoxic concentration: 60000 nM
Estimate against measurement, compound 4: 2.4-fold (0.38 log units) below; low and high end bracket the measured number.
By their numbers in this assay, from the lowest: compounds 2, 1 and 4 (each within the scatter of the next). At a limit, above all of these: compound 3.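

In this assay, nitro on this aromatic carbon, para to a large group, gives a 2.0-fold higher number from compound 2 to compound 4 (0.30 log units; within the scatter), and nitro in place of methyl at the same carbon gives a 1.2-fold higher number from compound 1 to compound 4 (0.08 log units; within the scatter). Hydrogen, methyl and nitro at this one place therefore cannot be told apart in this assay, so the entry of 3 heavy atoms, where the earlier step only exchanged methyl and hydrogen, still leaves every step within the scatter. Only compound 3 is reported as a limit and not a number: the limit of > 100000 nM in this assay, at which 1 of the 4 values shown sits.

Going by these compounds, whether an amine or a carboxylic acid at this carbon would also stay within the scatter remains open. On these data alone, it is equally open whether a longer chain on the shared core would move the number beyond it.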